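Replacing the naphthyl group of compound 1 with 2-fluorophenyl

The compounds below may be only part of what the source reports. "The series", "measured", "known", "first", "only" and "open" are said of these compounds alone.

Compound 1 `c1ccc2c(-c3cn4ccnc4c(-c4ccc5ncn(C6CCCCC6)c5c4)n3)cccc2c1` was tested in a functional assay on SK-MEL-5 cells (Homo sapiens) for inhibition, read by sulforhodamine B assay, with a stated time of 48 h, tested at 10 uM (a higher number here means more inhibition at the concentration tested (going by the name of the read-out), a lower number less inhibition), and gave 4.06%, which is the low end of the three numbers at hand. Compound 2 `Fc1ccc(-c2cn3ccnc3c(-c3ccc4ncn(C5CCCCC5)c4c3)n2)cc1` gives 7.36% in this assay, and compound 3 `Brc1ccc(-c2cn3ccnc3c(-c3ccc4ncn(C5CCCCC5)c4c3)n2)cc1` gives 23.6%. The step of a number 3.3 percentage points higher from compound 1 to compound 2 (within the scatter) stays within the scatter, whereas the step of a number 19.5 percentage points higher from compound 1 to compound 3 (beyond the scatter) and the step of a number 16.2 percentage points higher from compound 2 to compound 3 (beyond the scatter) both lie beyond it.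

Compound 4 `Fc1ccccc1-c1cn2ccnc2c(-c2ccc3ncn(C4CCCCC4)c3c2)n1` differs from compound 1 in one place: 2-fluorophenyl in place of naphthalen-1-yl on an aromatic carbon. Within the data shown here, the step that bears most closely on this change is the one to compound 2, where a fluorinated phenyl also took the place of the naphthalen-1-yl group and the number moved by a number 3.3 percentage points higher from compound 1 to compound 2 (within the scatter), within the scatter. The larger move to compound 3 involved bromo, not fluoro, and so is less informative here. Compound 4 is therefore expected to show a step of about a number 2.9 percentage points higher from compound 1 to compound 4 (within the scatter), which is not beyond the scatter. For compound 4 the estimated value in this assay is 7%, with a range from 0% to 20%.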

Compound 4, a percentage reported as inhibition, at one concentration (the size of the read-out at that concentration, not a potency): 6.5%
The estimate for compound 4 lay 0.5 percentage points above the measured number; low and high end bracket the measured number.
By their numbers in this assay, from the lowest: compounds 1, 4 and 2 (each within the scatter of the next); then compound 3.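

At this aromatic carbon, 2-fluorophenyl cannot be told apart from naphthalen-1-yl in this assay, with a number 2.4 percentage points higher from compound 1 to compound 4 (within the scatter) and so a second fluorinated phenyl group gives the same reading as the first. Moving the fluoro from the 4-fluorophenyl to the 2-fluorophenyl arrangement also leaves the reading unresolved, with a number 0.9 percentage points lower from compound 2 to compound 4 (within the scatter) and the separation from the bromo compound holds, with a number 17.1 percentage points lower from compound 3 to compound 4 (beyond the scatter) so that among these four compounds only compound 3 stands apart. Nothing at hand explains why compound 3 differs from the rest. Going by these compounds, whether chloro or methoxy on the phenyl group would stand apart from compound 2 as bromo does remains open, as does the effect of an amine or a carboxylic acid at this carbon. All four numbers come from one concentration and so say nothing about potency.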